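The source may hold more compounds than are shown below. What is called first, only, known or untested is meant among the compounds shown, and "the series" means these compounds.

Compounds measured so far, with their values in an ADME assay on BHK cells (Mesocricetus auratus) for cytotoxicity, read by MTT assay, with a stated time of 96 h; on this read-out lower numbers stand for higher toxicity in this test and higher numbers for lower toxicity in this test:

Compound 1, `FC(F)(F)c1cccc(NC(=S)Nc2cccc(Br)c2)c1`: 10000 nM
Compound 2, `C=C(C)CNC(=S)Nc1cccc(C(F)(F)F)c1`: a limit of the assay, > 100000 nM
Compound 3, `CC[C@H]1CC[C@H](c2ccc(NC(=S)Nc3cccc(C(F)(F)F)c3)cc2)CC1`: 10000 nM

Compound 3 stands level with compound 1 on the numbers shown, and the two differ only within the scatter. The value of compound 2 is a limit of the assay and not a number, as the limit of > 100000 nM in this assay, at which 1 of the 3 values shown sits, shows. Within the data shown here, the single measured step, an at least 10-fold higher number from compound 1 to compound 2 (1.00 log units; beyond the scatter), came with 2-methylprop-2-en-1-yl in place of 3-bromophenyl on an amide-type nitrogen, an exchange of the whole ring for a chain.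

Compound 4, `FC(F)(F)c1cccc(NC(=S)Nc2ccc(I)cc2)c1`, is not yet measured. It differs from compound 3 by iodo in place of 4-ethylcyclohexyl on an aromatic carbon. This change keeps the ring on the amide-type nitrogen and alters only the group para to a large group, so the measured step bears on it only loosely. Compound 1, which carries 3-bromophenyl, gives 10000 nM, the same number as compound 3 with its 4-ethylcyclohexyl, which suggests the ring itself sets the level here.

The account therefore expects no step beyond the scatter, no change at the digits printed from compound 3 to compound 4 (within the scatter). Compound 4 is estimated at 10000 nM, with a range from 3000 nM to 35000 nM.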

Compound 4, half-maximal cytotoxic concentration: 9400 nM
Compound 4: the middle estimate sits 1.1-fold (0.03 log units) above what was measured; the measured number falls inside the stated range.
By their numbers in this assay, from the lowest: compounds 4, 1 and 3 (each within the scatter of the next). At a limit, above all of these: compound 2.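

In this assay, the group on this aromatic carbon can be exchanged for one of very different size with no step beyond the scatter: a 1.1-fold lower number from compound 3 to compound 4 (0.03 log units; within the scatter), with iodo in place of 4-ethylcyclohexyl, while a 1.1-fold lower number from compound 1 to compound 4 (0.03 log units; within the scatter), with 4-iodophenyl in place of 3-bromophenyl on an amide-type nitrogen. Among compounds 1, 3 and 4, neither the size of that group nor the change between these two halogen-bearing rings separates the values, whereas the exchange of ring for chain now appears from a second ring-bearing compound, as an at least 10-fold lower number from compound 2 to compound 4 (1.02 log units; beyond the scatter), with 4-iodophenyl in place of 2-methylprop-2-en-1-yl on an amide-type nitrogen. Compound 2 still stands at a limit of the assay and not at a number: the limit of > 100000 nM in this assay, at which 1 of the 4 values shown sits.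

The compounds shown leave open whether this level holds when the ring on the amide-type nitrogen carries an amine or a carboxylic acid in place of a halogen or a carbon-only group. They also leave open whether a longer chain or a chain ending in a hydroxyl group on that nitrogen would stay at the limit of compound 2. Whether such a chain would instead match the level of the ring-bearing compounds is likewise not shown.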